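The compounds below may be only part of what the source reports. "The series", "measured", "known", "first", "only" and "open" are said of these compounds alone.

Among the measured compounds shown here, compound 2 `COc1cc(/C=C/C(=O)c2cccc(NC(=O)c3cccs3)c2)ccc1O` stands highest of the two compounds measured so far in a functional assay on HUVEC cells (Homo sapiens) for inhibition, tested at 2.5 ug/mL (a higher number here means a stronger effect of the compound at the concentration tested, a lower number a weaker effect), where compound 2 gives 71%. For the measured compounds named here, its nearest neighbour, compound 1 `COc1cc(/C=C/C(=O)c2cccc(NC(=O)C(C)C)c2)ccc1O`, gives 11% in this assay, and the only measured step is a number 60 percentage points higher from compound 1 to compound 2 (beyond the scatter). Compound 3 `COc1cc(/C=C/C(=O)c2cccc(NC(=O)c3ccc(Cl)cc3Cl)c2)ccc1O` differs from compound 2 by 2,4-dichlorophenyl in place of thiophen-2-yl on a carbonyl carbon. The measured step bears on this one only loosely: it replaced isopropyl with a ring, whereas here one ring replaces another, so the change is expected to stay modest, a number 9 percentage points lower from compound 2 to compound 3 (within the scatter). Compound 3 is therefore estimated at 62%, with a range from 38% to 84%.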

Compound 3, a percentage reported as inhibition, at one concentration (the size of the read-out at that concentration, not a potency): 29%
Compound 3: middle estimate off by 33 percentage points, on the high side; measured number below the stated range.
By their numbers in this assay, from the lowest: compound 1; then compound 3; then compound 2.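

At this place on a carbonyl carbon, one aromatic ring does not simply stand in for another in this assay: 2,4-dichlorophenyl in place of thiophen-2-yl gives a number 42 percentage points lower from compound 2 to compound 3 (beyond the scatter). Having an aromatic ring there is thus not enough for the high number of compound 2, though 2,4-dichlorophenyl in place of isopropyl still gives a number 18 percentage points higher from compound 1 to compound 3 (beyond the scatter). Nothing measured here explains the gap between the two rings. The compounds shown leave open whether an unsubstituted phenyl or a furan-2-yl would stand nearer compound 2 or compound 3, and so whether the loss goes with the two chlorines or with the six-membered ring.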